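Swapping the anilino aryl group in a quinazoline-type series

This account rests on a few compounds, and the source may have more. Where it says the series, first, only, none or still open, it means among the compounds named here.

Among the compounds with values here, compound 3 `COc1ccccc1Nc1nc(SCc2ccc(C(F)(F)F)cc2)nc2ccccc12` gives 14100 nM in a functional assay on PC-3 cells (Homo sapiens) for cytotoxicity, read by MTT assay, with a stated time of 72 h (a higher number here means a weaker inhibitor, a lower number a stronger inhibitor), the lowest of the three numbers so far. Compound 1 `CCCCCCCCCCCCNc1nc(SCc2ccc(C(F)(F)F)cc2)nc2ccccc12` gives 26000 nM in this assay, which lies within the scatter of compound 3, so no order between them can be claimed. Within the data shown here, compound 2 `FC(F)(F)c1ccc(CSc2nc(Nc3ccccc3C(F)(F)F)c3ccccc3n2)cc1` gives 34800 nM, and the only single-point step, a 2.5-fold lower number from compound 2 to compound 3 (0.39 log units; beyond the scatter), is modest but beyond the scatter. Compound 4 `FC(F)(F)c1ccc(CSc2nc(Nc3ccc(Cl)cc3)c3ccccc3n2)cc1` has not yet been measured; it differs from compound 3 by 4-chlorophenyl in place of 2-methoxyphenyl on a nitrogen on an aromatic ring. Among the measured compounds shown here, no measured step changes the aryl group on this nitrogen in the same way, so the step from compound 2 to compound 3 is the closest guide: it shows that altering the substituent on this aryl ring moves the number only modestly. Compound 4 is therefore expected to lie near compound 3, with an expected step of a 1.4-fold higher number from compound 3 to compound 4 (0.15 log units; within the scatter) that may not exceed the scatter. The estimate for compound 4 in this assay is 20000 nM, with a range from 8000 nM to 50000 nM.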

Compound 4, half-maximal inhibitory concentration: 7110 nM
Beside the measured number, compound 4's estimate is 2.8-fold (0.45 log units) above it; the measured number lies below the stated range.
By their numbers in this assay, from the lowest: compounds 4, 3, 1 and 2 (each within the scatter of the next, the first and the last beyond it).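

With 4-chlorophenyl on this nitrogen, the aryl group no longer carries its substituent as in 2-methoxyphenyl or 2-(trifluoromethyl)phenyl, and the number in this assay does not rise. The change from 2-(trifluoromethyl)phenyl gives a 4.9-fold lower number from compound 2 to compound 4 (0.69 log units; beyond the scatter), a second step at this position that is beyond the scatter. The change from 2-methoxyphenyl gives a 2.0-fold lower number from compound 3 to compound 4 (0.30 log units; within the scatter), so no order can be claimed between these two compounds. Nothing at hand bears on why the number follows the aryl group. As far as these compounds go, whether the chlorine itself or its place on the ring matters remains open, as does how a 4-methoxyphenyl or a 2-chlorophenyl group on this nitrogen would compare. The compounds shown also leave open how a carboxylic acid or an amine on this aryl ring would read.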